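Notes on the amide aryl substituent in the series

The compounds below may be only part of what the source reports. "The series", "measured", "known", "first", "only" and "open" are said of these compounds alone.

Of the compounds shown here, three have been measured in an assay on HEK293 cells for antagonist activity at P2X purinoceptor 7 (Homo sapiens), read by fluorescence, with a stated time of 2 h; a lower number here means a stronger inhibitor, a higher number a weaker inhibitor. Compound 1 `CS(=O)(=O)c1ccc(C(=O)N2CCC(n3cncc3-c3ccc(OS(=O)(=O)c4cccc5cnccc45)cc3)CC2)cc1` gives 25 nM. Compound 2 `CC(C)c1ccc(C(=O)N2CCC(n3cncc3-c3ccc(OS(=O)(=O)c4cccc5cnccc45)cc3)CC2)cc1` gives 55 nM, and compound 3 `CS(=O)(=O)c1ccc(C(=O)N2CCC(n3cncc3-c3ccc(OS(=O)(=O)c4cccc(C#N)c4)cc3)CC2)cc1` gives 143 nM. Compound 3 therefore stands highest of the three numbers: the step of a 5.7-fold higher number from compound 1 to compound 3 (0.76 log units; beyond the scatter) lies beyond the scatter, and the gap between compound 2 and compound 3 is also beyond the scatter. Among the compounds with values here, the only other measured step, a 2.2-fold higher number from compound 1 to compound 2 (0.34 log units; beyond the scatter), concerns the aryl group on the amide and is modest.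

Compound 4 `CN(C)c1ccc(C(=O)N2CCC(n3cncc3-c3ccc(OS(=O)(=O)c4cccc(C#N)c4)cc3)CC2)cc1` is not yet measured. It differs from compound 3 in one place: dimethylamino in place of methylsulfonyl on an aromatic carbon. Within the data shown here, no measured pair shows this exact exchange. Among the measured compounds shown here, the nearest precedent is the step of a 2.2-fold higher number from compound 1 to compound 2 (0.34 log units; beyond the scatter), where methylsulfonyl was likewise removed from the same aromatic carbon and replaced by another group; that step moved the number modestly upward. Here the same leaving group gives way to dimethylamino, so a modest shift toward a higher number in this assay is expected, with wide uncertainty since the entering group has no direct precedent. Compound 4 is thus estimated at 300 nM, with a range of 120 nM to 750 nM. The expected step is a 2.1-fold higher number from compound 3 to compound 4 (0.32 log units; beyond the scatter).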

Compound 4, half-maximal inhibitory concentration: 32 nM
Estimate against measurement, compound 4: 9.4-fold (0.97 log units) above; measured number below the stated range.
By their numbers in this assay, from the lowest: compounds 1, 4 and 2 (each within the scatter of the next, the first and the last beyond it); then compound 3.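

On the aromatic carbon para to a large group, methylsulfonyl is not required for a low number in this assay: dimethylamino in its place gives a 4.5-fold lower number from compound 3 to compound 4 (0.65 log units; beyond the scatter) with the 3-cyanophenyl group held on the sulfonyl sulfur. The earlier exchange at this same carbon, isopropyl for methylsulfonyl with isoquinolin-5-yl on the sulfonyl sulfur, gives a 2.2-fold higher number from compound 1 to compound 2 (0.34 log units; beyond the scatter) and so runs the other way, showing that removing methylsulfonyl has no single direction across these two pairs, although the entering group and the sulfonyl aryl group both differ between them. No measurement at hand bears on the reason for this difference in direction.

The two steps cannot separate the effect of the entering group from that of the sulfonyl aryl group, and that would take dimethylamino paired with isoquinolin-5-yl on the same scaffold. Also open, on these data alone, is how other groups at this carbon compare, such as a primary amine, a morpholine or a carboxylic acid, and whether the number follows the entering nitrogen or something else about dimethylamino.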